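The source may report more compounds than this note shows. Statements on the series, on what has been measured and on what is new or still open speak of the compounds shown alone.

Working notes on the series. Among the measured compounds shown here, compound 3 `COc1ccc2oc(CSC(=S)N3CCCCC3)cc(=O)c2c1` gives 1500 nM in a functional assay on MDA-MB-435S cells (Homo sapiens) for antiproliferative activity, read by MTT assay, with a stated time of 72 h (on this read-out lower numbers stand for stronger inhibition and higher numbers for weaker inhibition), the lowest number of the three measured so far; compound 1 `CCOC(=O)c1cc(=O)c2cc(CSC(=S)N(C(C)C)C(C)C)ccc2o1` gives 8100 nM, and compound 2 `COc1ccc2oc(CSC(=S)N(C(C)C)C(C)C)cc(=O)c2c1` gives 22100 nM. For the measured compounds named here, the only step that alters the amine on the thiocarbonyl carbon is a 15-fold lower number from compound 2 to compound 3 (1.17 log units; beyond the scatter), which shows that this position moves the read-out strongly. Compound 4 `COc1ccc2oc(CSC(=S)N3CCOCC3)cc(=O)c2c1` differs from compound 3 by morpholin-4-yl in place of piperidin-1-yl on a thiocarbonyl carbon. Going by the values given here, no measured step exchanges piperidin-1-yl for morpholin-4-yl, so the direction is not fixed by the data; a moderate loss against compound 3 is expected, smaller than the step that separates compound 2 from compound 3. Compound 4 is estimated at 3500 nM, range 1200 nM to 10000 nM, meaning a 2.3-fold higher number from compound 3 to compound 4 (0.37 log units; beyond the scatter).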

Compound 4, half-maximal inhibitory concentration: 3400 nM
The estimate for compound 4 lay 1.0-fold (0.01 log units) above the measured number; measured number inside the range.
By their numbers in this assay, from the lowest: compound 3; then compound 4; then compound 1; then compound 2.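

Among the compounds shown here, exchanging piperidin-1-yl for morpholin-4-yl on the thiocarbonyl carbon gives a 2.3-fold higher number from compound 3 to compound 4 (0.36 log units; beyond the scatter), which fixes a direction the earlier compounds left open: this exchange raises the number, and the step is modest. Morpholin-4-yl also gives a 6.5-fold lower number from compound 2 to compound 4 (0.81 log units; beyond the scatter), so in this pair too a six-membered non-aromatic ring gives a lower number than diisopropylamino, and that drop is not confined to piperidin-1-yl. No evidence is available to explain the difference between the two rings. On these data alone, whether a pyrrolidine or piperazine ring at this position would continue the order remains open. So does whether the order of the amines holds on the core of compound 1.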